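This account rests on a few compounds, and the source may have more. Where it says the series, first, only, none or still open, it means among the compounds named here.

Measured in a functional assay on MDA-MB-231 cells (Homo sapiens) for inhibition, read by sulforhodamine B assay, with a stated time of 48 h; a higher number here means a weaker inhibitor of growth, a lower number a stronger inhibitor of growth:
compound 1, `COc1cc(-c2nn(-c3cccc(NC(=O)Nc4cccc(C(F)(F)F)c4)c3)cc2-c2ccncc2)ccc1Cl`: 811 nM
compound 2, `COc1cc(-c2nn(-c3cccc(NC(=O)Nc4ccc(Cl)c(C(F)(F)F)c4)c3)cc2-c2ccncc2)ccc1Cl`: 760 nM

Going by the values given here, compound 2 stands level with compound 1 in this assay; the single step joining them, a 1.1-fold lower number from compound 1 to compound 2 (0.03 log units; within the scatter), is within the scatter, so neither can be set above the other. Compound 3, `COc1cc(-c2nn(-c3cccc(NC(=O)c4ccccc4)c3)cc2-c2ccncc2)ccc1Cl`, is the next point and differs from compound 2 in one place: phenyl in place of (4-chloro-3-(trifluoromethyl)phenyl)amino on a carbonyl carbon. With the leaving group go its hydrogen-bond donor, its chloro and its trifluoromethyl, and the urea of compound 2 becomes a plain amide. Among the compounds with values here, no measured step touches this part of the molecule: the only step known, a 1.1-fold lower number from compound 1 to compound 2 (0.03 log units; within the scatter), concerns one substituent on the leaving ring and says nothing about removing the whole arylamino group. The expectation therefore rests on the size of the change alone. Taking away so much of the molecule is expected to weaken growth inhibition in this assay, that is, to raise the number, by roughly a 4.6-fold higher number from compound 2 to compound 3 (0.66 log units; beyond the scatter), with wide uncertainty. Compound 3 is thus estimated at 3500 nM, with a range from 800 nM to 15000 nM.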

Compound 3, concentration for 50% growth inhibition: 1170 nM
Beside the measured number, compound 3's estimate is 3.0-fold (0.48 log units) above it, within the range that was stated.
By their numbers in this assay, from the lowest: compounds 2, 1 and 3 (each within the scatter of the next).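

At the carbonyl carbon, the whole arylamino group can give way to phenyl without a step that can be told from the scatter in this assay: a 1.5-fold higher number from compound 2 to compound 3 (0.19 log units; within the scatter) for the loss of (4-chloro-3-(trifluoromethyl)phenyl)amino, and a 1.4-fold higher number from compound 1 to compound 3 (0.16 log units; within the scatter) for the loss of (3-(trifluoromethyl)phenyl)amino. The earlier pair covered only a single chloro on the leaving ring, whereas these two steps show that the urea, with its hydrogen-bond donor, and the trifluoromethyl are both dispensable for a value in this range in this assay, and that the plain amide stands level with both ureas. No accompanying measurement bears on why the number holds across so large a change.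

The compounds shown leave open whether any group on the carbonyl carbon would separate from these three, for example a saturated amine such as morpholine or a longer alkyl chain in place of phenyl. Going by these compounds, it also remains open whether a chloro, a trifluoromethyl or a carboxylic acid on the phenyl of compound 3 would move the number beyond the scatter.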